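The source may hold more compounds than are shown below. What is called first, only, known or untested is meant among the compounds shown, and "the series" means these compounds.

Measured compounds in a functional assay on HepG2 cells (Homo sapiens) for cytotoxicity, read by MTT assay, with a stated time of 48 h; a higher number here means a weaker inhibitor, a lower number a stronger inhibitor: compound 1 `CCCCCCCCNC(=O)[C@@H](NC(=O)c1ccccc1)[C@@H](C)O` gives 136000 nM; compound 2 `C/C=C/C=C/C(=O)N[C@H](C(=O)NCCCCCCCC)[C@@H](C)O` gives 102000 nM.

Compound 1 stands with the highest of the two numbers in this assay, its nearest neighbour being compound 2 at a 1.3-fold lower number from compound 1 to compound 2 (0.12 log units; within the scatter), so the two cannot be told apart. That step swaps the group on the carbonyl carbon of the amide and leaves the octyl chain untouched.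

Compound 3 `CCCCCCCCCCCCNC(=O)[C@@H](NC(=O)c1ccccc1)[C@@H](C)O` is the unmeasured case. It differs from compound 1 by butyl in place of hydrogen on a saturated chain carbon, eight bonds along the chain from an amide-type nitrogen, the same difference read one bond further out as methyl to pentyl, ethyl to hexyl, propyl to heptyl. Among the measured compounds shown here, no measured step touches this chain, so nothing recorded bears on it. The expectation for compound 3 in this assay is therefore a step of about a 1.4-fold lower number from compound 1 to compound 3 (0.13 log units; within the scatter), essentially none beyond the scatter. The estimate for compound 3 is 100000 nM, with a range from 40000 nM to 250000 nM.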

Compound 3, half-maximal inhibitory concentration: > 400000 nM
Compound 3 was reported as a limit; the forecaster's own chance of this, stated with the estimate: 20%; at least 4.0-fold (0.60 log units) between middle value and limit.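

Compound 3 is reported only as a limit in this assay: the limit of > 400000 nM in this assay, at which 1 of the 3 values shown sits.

Butyl in place of hydrogen on a saturated chain carbon, eight bonds along the chain from an amide-type nitrogen, gives an at least 2.9-fold higher number from compound 1 to compound 3 (0.46 log units; beyond the scatter), so this chain position does register in the read-out, and the lengthening goes with a weaker result. The earlier step on the carbonyl carbon, a 1.3-fold lower number from compound 1 to compound 2 (0.12 log units; within the scatter), did not separate its two compounds, which makes the chain the first place in the series where a change goes beyond the scatter.

The compounds shown leave open at what chain length, going upward from the octyl chain of compound 1, the number starts to rise, and whether a decyl chain fits that picture. Also open, from the compounds shown here alone, are whether the same lengthening holds on the penta-1,3-dien-1-yl amide of compound 2, and what an amine or a carboxylic acid on the chain would do.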